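The source may report more compounds than this note shows. Statements on the series, on what has been measured and on what is new or still open speak of the compounds shown alone.

Measured so far in a functional assay on the whole organism (strain albino Sprague-Dawley) with Rattus norvegicus as the target, in the maximal electroshock model; a lower number here means that less compound is needed, a higher number that more compound is needed for the effect:

- Compound 1, `COC[C@@H](N)C(=O)NCc1ccc(OCc2cccc(F)c2)cc1`: 13 mg/kg
- Compound 2, `CC(C)[C@@H](N)C(=O)NCc1ccc(Cl)cc1`: "not determined" (no result reported)
- Compound 3, `CC(C)(C)[C@@H](N)C(=O)NCc1ccc(OCc2cccc(F)c2)cc1`: > 30 mg/kg

Compound 1 gives a clear dose in this assay. For compound 3 the assay reports only a limit, > 30 mg/kg, and not a number; this is the limit of > 30 mg/kg in this assay, at which 1 of the 3 values shown sits. Between these two sits one measured change, an at least 2.3-fold higher number from compound 1 to compound 3 (0.36 log units; beyond the scatter), which is a swap on the chain carbon and not on the ring.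

Compound 2 stands nowhere on these numbers: for it this assay reports "not determined" (no result reported), so there is no starting value to build on.

Compound 4, `CC(C)[C@@H](N)C(=O)NCc1ccc(C(F)(F)F)cc1`, differs from compound 2 by trifluoromethyl in place of chloro on an aromatic carbon. For the measured compounds named here, no measured step touches that aromatic position; the only measured step concerns the chain carbon, so none of the measured data bears on this change, and no direction beyond the scatter can be argued for it. From the compounds shown here alone, the number of compound 2 is unknown as well.

With only the dose of compound 1 as a rough anchor, compound 4 is estimated to give 20 mg/kg in this assay, expected to fall between 6 mg/kg and 60 mg/kg.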

Compound 4, dose for half-maximal effect: 13 mg/kg
Compound 4: middle estimate off by 1.5-fold (0.19 log units), on the high side, within the range that was stated.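

Compound 2 has no number in this assay, so no step from it to compound 4 can be read, and nothing shown bears on the result of compound 4. The compounds shown leave open whether trifluoromethyl in place of chloro on the aromatic carbon shifts the dose at all.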